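Chloro to hydroxy on the aryl group of the shared core

A few compounds are considered here, and "the series" means these few. Any claim that something is new, unique, unknown or untested is made for them only; others in the source may bear on it.

Compound 3 `CN1CCN(c2nc(-c3ccc(Cl)cc3)nc3[nH]cnc23)CC1` carries 4-chlorophenyl on the shared core. In an assay on cells for displacement of a labelled ligand from adenosine receptor A3 (Homo sapiens), read by scintillation counting and radioligand binding, with a stated time of 180 min, tested at 10 uM (on this read-out lower numbers stand for less inhibition and higher numbers for more inhibition at the one concentration tested (going by the name of the read-out)), compound 3 gives > 80%, which is a limit of the assay and not a number. Compound 1 `CN1CCN(c2nc(-c3cccc(Cl)c3)nc3[nH]cnc23)CC1` carries 3-chlorophenyl instead. In this assay compound 1 gives > 80%, likewise a limit. Compound 2 `CN1CCN(c2nc(-c3cccc(O)c3)nc3[nH]cnc23)CC1` carries 3-hydroxyphenyl. In this assay compound 2 gives > 80%, again a limit. All three values sit at the limit of > 80% in this assay, at which 3 of the 3 values shown sit, so the steps a step that the two limits leave unreadable from compound 1 to compound 2, a step that the two limits leave unreadable from compound 1 to compound 3 and a step that the two limits leave unreadable from compound 2 to compound 3 cannot be read in size or direction.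

Compound 4 `CN1CCN(c2nc(-c3ccc(O)cc3)nc3[nH]cnc23)CC1` differs from compound 3 by hydroxy in place of chloro on an aromatic carbon. The closest comparison is the same hydroxy for chloro change, a step that the two limits leave unreadable from compound 1 to compound 2, where both ends are limits and no size is readable. Compound 4 is therefore expected to remain near the same limit, and the step that the limit leaves unreadable from compound 3 to compound 4 is estimated as small. The expected value of compound 4 in this assay is 86%, with a range from 70% to 98%.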

Compound 4, a percentage reported as inhibition, at one concentration (the size of the read-out at that concentration, not a potency): 48%
Beside the measured number, compound 4's estimate is 38 percentage points above it; measured number below the stated range.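

In this assay, within the data shown here, hydroxy in place of chloro on an aromatic carbon para to a large group is the first change with a readable effect: a number at least 32 percentage points lower from compound 3 to compound 4 (beyond the scatter). The placement of the hydroxy also matters, with a number at least 32 percentage points lower from compound 2 to compound 4 (beyond the scatter), and the change from 3-chlorophenyl to 4-hydroxyphenyl gives a number at least 32 percentage points lower from compound 1 to compound 4 (beyond the scatter), so among these four compounds the drop is seen only with 4-hydroxyphenyl. These steps are bounds only, and the steps among compounds 1, 2 and 3 cannot be read, because those three values are limits of the assay: the limit of > 80% in this assay, at which 3 of the 4 values shown sit.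

On these data alone, whether a methoxy group or an amine in place of the hydroxy of compound 4 would restore the read-out stays open. Also open, as far as these compounds go, is whether 3-chlorophenyl, 3-hydroxyphenyl and 4-chlorophenyl differ at all, since compounds 1, 2 and 3 give no separable numbers.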